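Ring size on a side chain in two quinoline-free cores

The source may hold more compounds than are shown below. What is called first, only, known or untested is meant among the compounds shown, and "the series" means these compounds.

Four compounds share one core and differ in two places. Compound 1, `Clc1ccc2c(NCCCN3CCCC3)ccnc2c1`, carries a chloro group on the aromatic part and a pyrrolidin-1-yl ring at the end of a three-carbon chain. In a functional assay on MCF7 cells (Homo sapiens) for antiproliferative activity, read by sulforhodamine B assay, with a stated time of 48 h (a lower number here means a stronger inhibitor of growth, a higher number a weaker inhibitor of growth), compound 1 gives 21500 nM. Compound 2, `Clc1ccc2c(NCCCN3CCCCC3)ccnc2c1`, differs from compound 1 by piperidin-1-yl in place of pyrrolidin-1-yl on a saturated chain carbon, three bonds along the chain from a nitrogen on an aromatic ring. In this assay compound 2 gives 17700 nM, and the step reads a 1.2-fold lower number from compound 1 to compound 2 (0.08 log units; within the scatter). Compound 3, `FC(F)(F)c1ccc2c(NCCCN3CCCC3)ccnc2c1`, differs from compound 1 by trifluoromethyl in place of chloro on an aromatic carbon; in this assay compound 3 gives 36800 nM, and the step is a 1.7-fold higher number from compound 1 to compound 3 (0.23 log units; within the scatter). Set beside compound 2, compound 3 shows the higher number of the two.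

Compound 4, `FC(F)(F)c1ccc2c(NCCCN3CCCCC3)ccnc2c1`, is the unmeasured member. It differs from compound 3 by piperidin-1-yl in place of pyrrolidin-1-yl on a saturated chain carbon, three bonds along the chain from a nitrogen on an aromatic ring. The place is described in the same words as for the change from compound 1 to compound 2, so this is the same change, now made on the core of compound 3 instead of the core of compound 1.

The expectation for compound 4 rests on that earlier step, because a 1.2-fold lower number from compound 1 to compound 2 (0.08 log units; within the scatter) stayed within the scatter, and on the starting point of compound 3 at 36800 nM. The step from compound 3 to compound 4 is therefore estimated to be small, about a 1.2-fold lower number from compound 3 to compound 4 (0.09 log units; within the scatter). Compound 4 is thus expected to give roughly 30000 nM in this assay, with a likely range from 15000 nM to 60000 nM.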

Compound 4, concentration for 50% growth inhibition: 32600 nM
Compound 4: middle estimate off by 1.1-fold (0.04 log units), on the low side, and the stated range covers the measured number.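

On the core of compound 3, piperidin-1-yl in place of pyrrolidin-1-yl gives a 1.1-fold lower number from compound 3 to compound 4 (0.05 log units; within the scatter) in this assay, and this agrees with the same ring change on the core of compound 1: the same change on two cores in this assay, a 1.2-fold lower number (0.08 log units; within the scatter) from compound 1 to compound 2 and a 1.1-fold lower number (0.05 log units; within the scatter) from compound 3 to compound 4, 1.1-fold (0.03 log units) apart, within the scatter of two such steps

The second change, trifluoromethyl in place of chloro on an aromatic carbon, can now be read a second time, as a 1.8-fold higher number from compound 2 to compound 4 (0.27 log units; within the scatter), and it also agrees with its earlier counterpart: the same change on two cores in this assay, a 1.7-fold higher number (0.23 log units; within the scatter) from compound 1 to compound 3 and a 1.8-fold higher number (0.27 log units; within the scatter) from compound 2 to compound 4, 1.1-fold (0.03 log units) apart, within the scatter of two such steps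

Across these four compounds, each change therefore gives a similar result on both cores, but every one of the four steps lies within the scatter, so this shows only that a small step stayed small; it does not show that a larger effect would carry over in the same way, and each comparison rests on a single pair of steps in a single assay.

The compounds shown leave open whether a different end group on the chain, such as a morpholin-4-yl ring or a dimethylamino group, or a longer chain, would move the number beyond the scatter. They also leave open how a nitrile or a methoxy group on the aromatic carbon that carries chloro or trifluoromethyl here would behave, and whether such a step would carry from one core to another.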